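The source may hold more compounds than are shown below. What is called first, only, known or untested is meant among the compounds shown, and "the series" means these compounds.

Going by the values given here, in a functional assay on NCI-H322M cells (Homo sapiens) for inhibition (a higher number here means a weaker inhibitor of growth, a lower number a stronger inhibitor of growth), two compounds built on one shared core have numbers so far. Compound 1 `NC(=O)c1cc(Cl)ccc1NC(=O)COc1ccccc1`, which carries a chloro group, gives 7090 nM. Compound 2 `NC(=O)c1cc(I)ccc1NC(=O)COc1ccccc1`, which carries iodo on the same aromatic carbon, gives 705 nM. That is the lower of the two numbers, so compound 2 is the stronger growth inhibitor of the pair. Among the compounds with values here, the swap of chloro for iodo is the only measured step, a 10-fold lower number from compound 1 to compound 2 (1.00 log units; beyond the scatter), and it lies beyond the scatter.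

Compound 3 `COc1ccc(NC(=O)COc2ccccc2)c(C(N)=O)c1` changes that same carbon again, with methoxy in place of iodo on an aromatic carbon. Within the data shown here, no methoxy compound has been measured, so the chloro-to-iodo step is only an indirect guide. Because compound 1 gave 7090 nM without the iodo, a move away from iodo is expected to raise the number, though by somewhat less than the measured step. The expected change is a 5.7-fold higher number from compound 2 to compound 3 (0.75 log units; beyond the scatter). For compound 3 the estimated value is 4000 nM, with an expected range from 1200 nM to 13000 nM.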

Compound 3, concentration for 50% growth inhibition: 2100 nM
The estimate for compound 3 lay 1.9-fold (0.28 log units) above the measured number, and the stated range covers the measured number.
By their numbers in this assay, from the lowest: compound 2; then compound 3; then compound 1.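

In this assay, methoxy in place of iodo gives a 3.0-fold higher number from compound 2 to compound 3 (0.47 log units; beyond the scatter) and methoxy in place of chloro gives a 3.4-fold lower number from compound 1 to compound 3 (0.53 log units; beyond the scatter) so this aromatic carbon now carries three groups in a clear order, with methoxy falling between the two halogens and each gap beyond the scatter. Going by these compounds alone, this is the first sign that the number at this position does not depend on a halogen alone: methoxy, with two heavy atoms and one hydrogen-bond acceptor where iodo has one heavy atom and no acceptor, still gives a lower number than chloro, though not one as low as iodo. No available data explain why the three groups fall in this order.

Three groups cannot show whether an amine, a carboxylic acid or a longer chain such as ethoxy on this carbon would land near iodo, near chloro or outside that span altogether. On these data alone, it also remains open whether the same order would hold if the carbamoyl group or the rest of the shared core were changed.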